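Compound 4: losing carbamoyl at the limit

A few compounds are considered here, and "the series" means these few. Any claim that something is new, unique, unknown or untested is made for them only; others in the source may bear on it.

Measured so far in a toxicity assay on CCRF-CEM cells (Homo sapiens) for cytotoxicity (on this read-out lower numbers stand for higher toxicity in this test and higher numbers for lower toxicity in this test), for the series:
compound 1 `COc1cccc2c1nc(-c1c(F)cccc1F)n2Cc1c(F)cccc1F` gives 44.3 uM as a number
compound 2 `Fc1cccc(F)c1Cn1c(-c2c(F)cccc2F)nc2c(Cl)cccc21` gives 30.4 uM as a number
compound 3 `NC(=O)c1cccc2c1nc(-c1c(F)cccc1F)n2Cc1c(F)cccc1F` gives > 100 uM as a limit, not a number

Compound 3 is known only through the limit of > 100 uM in this assay, at which 1 of the 3 values shown sits, and has no exact place in the series. Compound 4 `CC(C)=CCc1cccc2c1nc(-c1c(F)cccc1F)n2Cc1c(F)cccc1F` carries 3-methylbut-2-en-1-yl in place of carbamoyl on an aromatic carbon and has not been measured. Two steps bring carbamoyl in: an at least 2.2-fold higher number from compound 1 to compound 3 (0.35 log units; beyond the scatter) and an at least 3.2-fold higher number from compound 2 to compound 3 (0.51 log units; beyond the scatter) are both modest at least. Without carbamoyl, a 1.5-fold lower number from compound 1 to compound 2 (0.16 log units; within the scatter) stays small. Removing carbamoyl is therefore expected to reverse those steps, giving an at least 3.3-fold lower number from compound 3 to compound 4 (0.52 log units; beyond the scatter) as the expected move in this assay toward a lower number. The estimate for compound 4 is 30 uM with an expected span from 12 uM to 75 uM in this estimate.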

Compound 4, half-maximal toxic concentration: 28.3 uM
Compound 4: middle estimate off by 1.1-fold (0.03 log units), on the high side; the measured number falls inside the stated range.
By their numbers in this assay, from the lowest: compounds 4, 2 and 1 (each within the scatter of the next). At a limit, above all of these: compound 3.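

In this assay, 3-methylbut-2-en-1-yl, a chain of 5 carbon atoms, sits level with chloro and methoxy at this position: a 1.1-fold lower number from compound 2 to compound 4 (0.03 log units; within the scatter) and a 1.6-fold lower number from compound 1 to compound 4 (0.19 log units; within the scatter) show no separation beyond the scatter. Among the four groups shown here, carbamoyl alone stands apart, and an at least 3.5-fold lower number from compound 3 to compound 4 (0.54 log units; beyond the scatter) now makes this a third comparison on that side. Compound 3 is still held only by a limit, not a number: the limit of > 100 uM in this assay, at which 1 of the 4 values shown sits.

From the compounds shown here alone, how far carbamoyl actually stands apart remains open. Also open, going by these compounds, is whether an amine, a carboxylic acid or a longer chain at this position would separate likewise.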